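The compounds below may be only part of what the source reports. "The series", "measured", "known", "first", "only" and "open" are said of these compounds alone.

Measured so far in a functional assay on CCRF-CEM cells (Homo sapiens) for inhibition; a higher number here means a weaker inhibitor, a lower number a stronger inhibitor:
compound 1, `O=C1/C(=C/c2ccc(Br)cc2)Cc2ccccc21`: 284000 nM
compound 2, `Cc1ccc(/C=C2\Cc3ccccc3C2=O)cc1`: 67100 nM
compound 3, `O=C1/C(=C/c2ccc(Br)cc2)CCc2ccccc21`: > 500000 nM

The comparison of compound 1 with compound 2 rests on one change, (methyl in place of bromo on an aromatic carbon), and it gives a 4.2-fold lower number from compound 1 to compound 2 (0.63 log units; beyond the scatter). For compound 3 the value in this assay is a limit, not a number: the limit of > 500000 nM in this assay, at which 1 of the 3 values shown sits. How the core of compound 3 differs from the core of compound 1 is not broken down here; the two differ in more than one place.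

Compound 4, `Cc1ccc(/C=C2\CCc3ccccc3C2=O)cc1`, has not yet been tested in this assay. It stands to compound 3 as compound 2 stands to compound 1: the change is methyl in place of bromo on an aromatic carbon, and the place of the change reads the same, word for word, in both pairs, so it is the same change made on the core of compound 3 rather than on the core of compound 1. Since compound 3 shows only a limit, the expected step from compound 3 to compound 4 cannot be anchored to a number; it is estimated, following the earlier step, as an at least 2.0-fold lower number from compound 3 to compound 4 (0.30 log units; that floor lies within the scatter). On that basis compound 4 is expected to give about 250000 nM in this assay, most likely between 80000 nM and 1000000 nM, with a real chance that the assay again reports only a limit.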

Compound 4, half-maximal inhibitory concentration: 460000 nM
Compound 4: middle estimate off by 1.8-fold (0.26 log units), on the low side; the measured number falls inside the stated range.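

Carried to the other core, methyl in place of bromo gives an at least 1.0-fold lower number from compound 3 to compound 4 (0.03 log units; that floor lies within the scatter) in this assay, and set beside the earlier step the two read as follows: the same change on two cores in this assay, a 4.2-fold lower number (0.63 log units; beyond the scatter) from compound 1 to compound 2 and an at least 1.0-fold lower number (0.03 log units; that floor lies within the scatter) from compound 3 to compound 4; the limit leaves it open whether they differ

The value for compound 3 is a limit, not a number: the limit of > 500000 nM in this assay, at which 1 of the 4 values shown sits.

Going by these compounds alone, what this shows is only that compound 4 does not go against the direction of the earlier step; it does not show that the change carries from one core to the other with the same size, nor that its size shrinks on the second core, since the printed floor lies within the scatter and the true step could be larger.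

The compounds shown carry only bromo or methyl at this place, on two cores, so they leave open how an amine, a carboxylic acid or a longer alkyl chain would read there in this assay. They also leave open whether the step would hold on any further core, and how the two cores themselves compare, as they differ in more than one place.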